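A longer chain on the aryl nitrogen of compound 3

The source may report more compounds than this note shows. Statements on the series, on what has been measured and on what is new or still open speak of the compounds shown alone.

The measured compounds and their values:
Compound 1 `CCN(Cc1cccc(Br)c1)c1ccc(C(=O)N2CCc3ccc(OS(N)(=O)=O)cc3C2)cc1`: 80.2% in an assay on HEK293 cells for inhibition of Steryl-sulfatase (Homo sapiens), tested at 0.1 uM; a higher number here means a stronger effect of the compound at the concentration tested, a lower number a weaker effect
Compound 2 `CCN(Cc1cccnc1)c1ccc(C(=O)N2CCc3ccc(OS(N)(=O)=O)cc3C2)cc1`: 35.7%
Compound 3 `CCN(Cc1ccccc1)c1ccc(C(=O)N2CCc3ccc(OS(N)(=O)=O)cc3C2)cc1`: 66.9%

Compound 3 stands second highest of the three numbers. The nearest number belongs to compound 1, as a number 13.3 percentage points lower from compound 1 to compound 3 (beyond the scatter) shows; the furthest belongs to compound 2, as a number 31.2 percentage points higher from compound 2 to compound 3 (beyond the scatter) shows. Compound 4 `CCCN(Cc1ccccc1)c1ccc(C(=O)N2CCc3ccc(OS(N)(=O)=O)cc3C2)cc1` is not yet measured. It differs from compound 3 in one place: methyl in place of hydrogen on a saturated chain carbon, two bonds along the chain from a nitrogen on an aromatic ring.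

None of the three measured steps touches this place. Each of them, a number 44.5 percentage points lower from compound 1 to compound 2 (beyond the scatter), a number 13.3 percentage points lower from compound 1 to compound 3 (beyond the scatter) and a number 31.2 percentage points higher from compound 2 to compound 3 (beyond the scatter), changes the aromatic group on the saturated chain carbon bound to the nitrogen on the aromatic ring, while the ethyl on that nitrogen stays the same throughout. The measured steps therefore say nothing direct about lengthening that chain by one carbon, and the change itself is small in count. The expectation is a step of no size beyond the scatter, in no preferred direction, with a range widened by the lack of any bearing step. Compound 4 is expected to give 67%, between 50% and 82%. The expected step is a number 0.1 percentage points higher from compound 3 to compound 4 (within the scatter).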

Compound 4, a percentage reported as inhibition, at one concentration (the size of the read-out at that concentration, not a potency): 64.8%
For compound 4 the middle estimate is 2.2 percentage points above the measured one; low and high end bracket the measured number.
By their numbers in this assay, from the lowest: compound 2; then compounds 4 and 3 (each within the scatter of the next); then compound 1.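

In this assay, among the compounds shown here, the step of a number 2.1 percentage points lower from compound 3 to compound 4 (within the scatter) gives the first reading at this place: going from ethyl to propyl, with methyl entering on a saturated chain carbon, two bonds along the chain from a nitrogen on an aromatic ring, produces no change that can be told from the scatter. With the benzyl group held, the longer chain therefore leaves the read-out at the tested concentration unresolved from that of compound 3, whereas each step among compound 1, compound 2 and compound 3, all made on the aromatic group, lies beyond the scatter. The steps of a number 29.1 percentage points higher from compound 2 to compound 4 (beyond the scatter) and a number 15.4 percentage points lower from compound 1 to compound 4 (beyond the scatter) alter the chain and the aromatic group together, so they cannot be read for either change alone. Nothing available explains why the propyl and ethyl compounds read alike.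

As far as these compounds go, whether butyl or a still longer chain on that nitrogen would also leave the read-out unresolved remains open. Also open, from the compounds shown here alone, is whether propyl would behave the same alongside the 3-bromobenzyl group of compound 1 or the pyridin-3-yl group of compound 2.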